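Swapping the Nitrophenyl Group for a Carbamoylpyridine

The source may report more compounds than this note shows. Statements on the series, on what has been measured and on what is new or still open speak of the compounds shown alone.

Compound 1: `O=C(CCCCCCc1ccccc1)c1ncc(-c2ccc([N+](=O)[O-])cc2)o1` — 50 nM
Compound 2: `COC(=O)c1ccc(-c2cnc(C(=O)CCCCCCc3ccccc3)o2)nc1` — 3.5 nM

Both compounds were tested in an assay (Rattus norvegicus) for inhibition of Fatty-acid amide hydrolase 1 (Homo sapiens); on this read-out lower numbers stand for stronger inhibition and higher numbers for weaker inhibition. Compound 1 gives 50 nM, the higher of the two numbers, so it is the weaker of the pair. Compound 2, which carries a pyridine bearing a methyl ester instead of the nitrophenyl group, gives 3.5 nM, a gap that lies beyond the usual scatter.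

The unmeasured compound 3, `NC(=O)c1cccc(-c2cnc(C(=O)CCCCCCc3ccccc3)o2)n1`, shares the core of compound 1 and differs in one place: 6-carbamoylpyridin-2-yl in place of 4-nitrophenyl on an aromatic carbon. The pyridine of compound 2 went with a much lower number, and compound 3 also carries a pyridine, here with an amide in place of the ester. Compound 3 is therefore expected to follow compound 2 rather than compound 1, with the step of a 13-fold lower number from compound 1 to compound 3 (1.10 log units; beyond the scatter) expected to be a clear drop beyond the scatter. The estimate for compound 3 is 4 nM, with a range from 1 nM to 15 nM.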

Compound 3, inhibition constant: 1 nM
The estimate for compound 3 lay 4.0-fold (0.60 log units) above the measured number; the range from low to high includes it.
By their numbers in this assay, from the lowest: compound 3; then compound 2; then compound 1.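

In this assay, placing 6-carbamoylpyridin-2-yl instead of 4-nitrophenyl on the aromatic carbon next to the ring oxygen gives a 50-fold lower number from compound 1 to compound 3 (1.70 log units; beyond the scatter). This shows that the position accepts a primary amide on a pyridine ring and that the change goes with much stronger inhibition, even though the two groups have the same number of heavy atoms. The entering group brings a ring nitrogen and a hydrogen-bond donor, but no evidence here ties the step to either of them.

The compounds shown do not separate the effect of the pyridine nitrogen from that of the amide, since both enter in one step. A plain pyridin-2-yl group, or a carboxylic acid in place of the amide, would leave open how much each part contributes.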